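The source may hold more compounds than are shown below. What is called first, only, known or untested is meant among the compounds shown, and "the series" means these compounds.

Compound 1 `CNC(=O)c1cc(Oc2ccc(NC(=O)c3cc(-c4ccc(Cl)cc4)ncn3)cc2F)ccn1`: > 100000 nM (a limit)
Compound 2 `CNC(=O)c1cc(Oc2ccc(NC(=O)c3cc(-c4ccc(Br)cc4)ncn3)cc2F)ccn1`: > 100000 nM (a limit)
Compound 3 `CNC(=O)c1cc(Oc2ccc(NC(=O)c3cc(-c4ccc(C)cc4)ncn3)cc2F)ccn1`: 13200 nM

Within the data shown here, in a functional assay on A549 cells (Homo sapiens) for cytotoxicity, read by MTT assay, with a stated time of 72 h (a higher number here means a weaker inhibitor, a lower number a stronger inhibitor), compound 3 gives 13200 nM, the only value in this small set that is an actual number. Compound 1 reads > 100000 nM, which is a limit of the assay. Compound 2 reads > 100000 nM, which is also a limit.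

Compound 4 `CNC(=O)c1cc(Oc2ccc(NC(=O)c3cc(-c4ccc(F)cc4)ncn3)cc2F)ccn1` differs from compound 3 by fluoro in place of methyl on an aromatic carbon, a change from 4-methylphenyl to 4-fluorophenyl.

Among the measured compounds shown here, two measured steps bear on this change, both ending at the methyl group: an at least 7.5-fold lower number from compound 1 to compound 3 (0.87 log units; beyond the scatter) and an at least 7.5-fold lower number from compound 2 to compound 3 (0.87 log units; beyond the scatter). Both rest on (the limit of > 100000 nM in this assay, at which 2 of the 3 values shown sit). Going from methyl to fluoro runs the opposite way, from methyl back to a halogen, so in this assay a higher number is expected. The expected change is a 3.0-fold higher number from compound 3 to compound 4 (0.48 log units; beyond the scatter), though a reading at the limit remains possible. For compound 4 the estimated value is 40000 nM, with an expected range of 12000 nM to 100000 nM.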

Compound 4, half-maximal inhibitory concentration: > 100000 nM
Compound 4: a limit, no number (the forecaster's own chance of this, stated with the estimate: 35%); at least 2.5-fold (0.39 log units) between middle value and limit.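

In this assay, compound 4 gives > 100000 nM, which is a limit and not a number. The step back from methyl to fluoro is an at least 7.5-fold higher number from compound 3 to compound 4 (0.87 log units; beyond the scatter), so a third halogen on the aromatic carbon para to a large group joins chloro and bromo at the limit, and among these four compounds only the methyl group gives a measured value. The steps among the three halogen compounds cannot be read, and fluoro, chloro and bromo cannot be ranked against each other, because all of them stop at the same ceiling: the limit of > 100000 nM in this assay, at which 3 of the 4 values shown sit.

On these data alone, whether a measured value at this place is particular to methyl, or also appears with ethyl, methoxy or an amine, stays open. As far as these compounds go, how weak the three halogen compounds really are also remains unknown.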